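Fixing the Hydroxyl-Bearing Chain Carbon of Compound 3

The source may report more compounds than this note shows. Statements on the series, on what has been measured and on what is new or still open speak of the compounds shown alone.

Compound 1, `CCCCC(O)CC(=O)O[C@H](CC=C(C)C)C1=CC(=O)c2c(O)ccc(O)c2C1=O`: 45300 nM
Compound 2, `CC(=O)OCCC(=O)O[C@H](CC=C(C)C)C1=CC(=O)c2c(O)ccc(O)c2C1=O`: 15700 nM
Compound 3, `CCC(C)(O)CC(=O)O[C@H](CC=C(C)C)C1=CC(=O)c2c(O)ccc(O)c2C1=O`: 16000 nM

Three esters of a shared core have been measured in a functional assay on DU-145 cells (Homo sapiens) for cytotoxicity, read by MTT assay; a higher number here means a weaker inhibitor, a lower number a stronger inhibitor. Compound 1 gives 45300 nM, compound 2 gives 15700 nM and compound 3 gives 16000 nM. Compound 3 stands second highest of the three; its nearest neighbour is compound 2, within the scatter, and its furthest is compound 1, from which it is separated by a step beyond the scatter.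

The measured steps are a 2.9-fold lower number from compound 1 to compound 2 (0.46 log units; beyond the scatter), a 2.8-fold lower number from compound 1 to compound 3 (0.45 log units; beyond the scatter) and a 1.0-fold higher number from compound 2 to compound 3 (0.01 log units; within the scatter). Each of them swaps one group for another on the saturated chain carbon bound to a carbonyl carbon.

Going by the values given here, compound 4 is `CC[C@](C)(O)CC(=O)O[C@H](CC=C(C)C)C1=CC(=O)c2c(O)ccc(O)c2C1=O`. the two compounds have the same atoms and bonds; at least one stereo element is drawn with a configuration in one of them and without one in the other: 1 of 2 stereo elements differ; a stereocentre at a saturated chain carbon is drawn without a configuration in compound 3 and S in compound 4 No measured step changes a stereocentre alone; the two groups exchanged in the steps above are not the same as setting one configuration at a centre already present. With the atoms and bonds unchanged, compound 4 is expected to sit close to compound 3, and the step of no change at the digits printed from compound 3 to compound 4 (within the scatter) is estimated to lie within the scatter. For compound 4 the estimate in this assay is 16000 nM, with a range from 7000 nM to 36000 nM.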

Compound 4, half-maximal inhibitory concentration: 20500 nM
Compound 4: middle estimate off by 1.3-fold (0.11 log units), on the low side, within the range that was stated.
By their numbers in this assay, from the lowest: compounds 2, 3 and 4 (each within the scatter of the next); then compound 1.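

In this assay, going by these compounds alone, setting the hydroxyl-bearing chain carbon to S gives a 1.3-fold higher number from compound 3 to compound 4 (0.11 log units; within the scatter), the first step here that touches a stereocentre alone, and it stays within the scatter. The placing of the group is also unchanged with the configuration set: a 1.3-fold higher number from compound 2 to compound 4 (0.12 log units; within the scatter), so the 1-hydroxy-1-methylpropyl and acetoxymethyl esters remain unseparated, while a 2.2-fold lower number from compound 1 to compound 4 (0.34 log units; beyond the scatter) keeps the 1-hydroxypentyl ester of compound 1 apart from compound 4 by a step beyond the scatter. The step from compound 3 therefore shows only that a defined S centre matches the undrawn one within the scatter, and it is no comparison of two opposite configurations, since what it rests on is this: the fact that one of compounds 3 and 4 is drawn with a defined configuration and the other without, at the place where they differ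

The compounds shown leave open how the R configuration at this carbon would compare with the S configuration of compound 4, and so whether this centre matters at all in this cytotoxicity read-out. They also leave open how an amine in place of the hydroxyl, or a longer chain on the same carbon, would read against compound 4.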